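This account rests on a few compounds, and the source may have more. Where it says the series, first, only, none or still open, it means among the compounds named here.

Of the compounds shown here, three have been measured in a functional assay on M21 cells (Homo sapiens) for antiproliferative activity, read by sulforhodamine B assay, with a stated time of 48 h; a lower number here means a stronger inhibitor, a higher number a weaker inhibitor. Compound 1 `Cc1ccccc1OS(=O)(=O)c1ccc(N2CCN(C)C2=O)cc1` gives 2900 nM. Compound 2 `COc1ccccc1OS(=O)(=O)c1ccc(N2CCN(C)C2=O)cc1` gives 21000 nM. Compound 3 `Cc1ccc(OS(=O)(=O)c2ccc(N3CCN(C)C3=O)cc2)cc1` reaches only a limit of the assay, > 100000 nM.

Compound 2 differs from compound 1 by methoxy in place of methyl on an aromatic carbon, and that change made a 7.2-fold higher number from compound 1 to compound 2 (0.86 log units; beyond the scatter). Compound 3 differs from compound 1 by 4-methylphenyl in place of 2-methylphenyl on an oxygen; here the change made an at least 34-fold higher number from compound 1 to compound 3 (1.53 log units; beyond the scatter), and between compound 2 and compound 3 there is an at least 4.7-fold higher number from compound 2 to compound 3 (0.67 log units; beyond the scatter). Compound 3 itself sits at the limit of > 100000 nM in this assay, at which 1 of the 3 values shown sits, so its own value is a limit, not a number.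

Compound 4 `COc1ccc(OS(=O)(=O)c2ccc(N3CCN(C)C3=O)cc2)cc1` is not yet measured. It differs from compound 3 by methoxy in place of methyl on an aromatic carbon. Among the compounds with values here, this is the same kind of change as the one from compound 1 to compound 2, but not the same: there the entering methoxy stands ortho to a large group, here it stands para to a large group.

Since compound 1 to compound 2 gave a 7.2-fold higher number from compound 1 to compound 2 (0.86 log units; beyond the scatter), a step of similar direction is expected from compound 3, so compound 4 is expected to show a step that the limit leaves unreadable from compound 3 to compound 4. Compound 4 is therefore estimated at 300000 nM, between 100000 nM and 1500000 nM, most likely reported again only as a limit.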

Compound 4, half-maximal inhibitory concentration: > 100000 nM
Compound 4: a limit, no number (the forecaster's own chance of this, stated with the estimate: 85%); the middle value does not contradict the limit.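

In this assay compound 4 gives > 100000 nM, which is a limit of the assay and not a number, and compound 3 stands at that same limit: the limit of > 100000 nM in this assay, at which 2 of the 4 values shown sit.

As far as these compounds go, every step between the two limits therefore cannot be read, so the change from 4-methylphenyl to 4-methoxyphenyl neither repeats nor contradicts the methoxy-for-methyl step measured on the other pair, a 7.2-fold higher number from compound 1 to compound 2 (0.86 log units; beyond the scatter), and the transfer of that step remains untested. What can be read are an at least 4.7-fold higher number from compound 2 to compound 4 (0.67 log units; beyond the scatter) and an at least 34-fold higher number from compound 1 to compound 4 (1.53 log units; beyond the scatter), so among these four compounds the 2-methylphenyl and 2-methoxyphenyl compounds give numbers while the 4-methylphenyl and 4-methoxyphenyl compounds do not, with no exception.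

The compounds shown leave open whether any group in place of the methyl of compound 3, such as an amine or a carboxylic acid, would bring a number within the range of the assay. They also leave open how a longer chain in place of the methyl of compound 1 would read.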